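Working notes: furanone series, compound 2 to compound 4

The source may hold more compounds than are shown below. What is called first, only, known or untested is meant among the compounds shown, and "the series" means these compounds.

Measured so far:
- compound 1 `Nc1ncn(CCC2(N)OC(=O)C(OCc3ccccc3)=C2OCc2ccccc2)c(=O)n1`; in a functional assay on SW-620 cells (Homo sapiens) for inhibition, read by MTT assay, with a stated time of 72 h (on this read-out higher numbers stand for weaker inhibition and lower numbers for stronger inhibition), compound 1 gives > 100000 nM, a limit of the assay.
- compound 2 `Nc1ccn(C[C@H](O)[C@H]2OC(=O)C(OCc3ccccc3)=C2OCc2ccccc2)c(=O)n1`; in this assay compound 2 gives > 100000 nM, a limit of the assay.
- compound 3 `O=C1O[C@H]([C@@H](O)Cn2ccc(NC(=O)c3ccccc3)nc2=O)C(OCc2ccccc2)=C1OCc1ccccc1`; in this assay compound 3 gives > 100000 nM, a limit of the assay.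

Compound 2 thus stands only at a limit in this assay, and the two further values shown are limits as well. Within the data shown here, the single step between measured compounds that differ in one place is a step that the two limits leave unreadable from compound 2 to compound 3, benzoyl in place of hydrogen on a nitrogen on an aromatic ring; the two limits leave its size unreadable, as all three values sit at the limit of > 100000 nM in this assay, at which 3 of the 3 values shown sit.

Compound 4 `O=C1O[C@H]([C@@H](O)Cn2c(=O)[nH]c(=O)[nH]c2=O)C(OCc2ccccc2)=C1OCc1ccccc1` is not yet measured. It differs from compound 2 by a group of 9 heavy atoms (3 carbon, 3 nitrogen, 3 oxygen; one six-membered aromatic ring with 3 hetero atoms) in place of a group of 8 heavy atoms (4 carbon, 3 nitrogen, 1 oxygen; one six-membered aromatic ring with 2 hetero atoms), on a saturated chain carbon, two bonds along the chain from an oxygen on a saturated carbon and a saturated ring carbon. Among the measured compounds shown here, no measured step reads on this change; the one step recorded is unreadable and bears on it only in that every value so far sits at the same limit. No step beyond the scatter is therefore expected in this assay in either direction. For compound 4 the expectation is that it stays at the limit. The estimate for compound 4 in this assay is 150000 nM, in the range 50000 nM to 500000 nM. The step from compound 2 to compound 4 is accordingly expected to be a step that the limit leaves unreadable from compound 2 to compound 4.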

Compound 4, half-maximal inhibitory concentration: > 100000 nM
Compound 4 was reported as a limit; the forecaster's own chance of this, stated with the estimate: 85%; the middle value does not contradict the limit.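

In this assay, among these compounds, compound 4 gives > 100000 nM as a limit of the assay, and compound 2 also stands at a limit, so no step between compound 2 and compound 4 can be read: the limit of > 100000 nM in this assay, at which 4 of the 4 values shown sit.

The compounds shown leave open whether in this assay any group in this place, or any change to the shared core, gives a value short of the limit.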